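The source may hold more compounds than are shown below. What is called first, only, known or untested is meant among the compounds shown, and "the series" means these compounds.

Compound 1 `C=CC(=O)Nc1cccc(NC(=O)CSc2nc(Nc3cccc([N+](=O)[O-])c3)c3ccccc3n2)c1`; compound 2 `C=CC(=O)Nc1cccc(NC(=O)CSc2nc(Nc3ccc(C(F)(F)F)cc3)c3ccccc3n2)c1`; compound 3 `C=CC(=O)Nc1cccc(NC(=O)CSc2nc(Nc3cc(OC)c(OC)c(OC)c3)c3ccccc3n2)c1`, not yet measured.

In a functional assay on MDA-MB-231 cells (Homo sapiens) for inhibition, read by MTT assay, with a stated time of 72 h (on this read-out lower numbers stand for stronger inhibition and higher numbers for weaker inhibition), compound 2 gives 11500 nM, the only number shown. Compound 1 reports only a limit in this assay, > 50000 nM (the limit of > 50000 nM in this assay, at which 1 of the 2 values shown sits). Within the data shown here, the sole measured step is an at least 4.3-fold lower number from compound 1 to compound 2 (0.63 log units; beyond the scatter), on the same nitrogen on an aromatic ring. The change to compound 3 is 3,4,5-trimethoxyphenyl in place of 4-(trifluoromethyl)phenyl on a nitrogen on an aromatic ring. Among the measured compounds shown here, no measured step exchanges these two groups, so that step is a weak guide. For compound 3 the expected step is a 1.0-fold higher number from compound 2 to compound 3 (0.02 log units; within the scatter), within the scatter. Compound 3 is expected to give 12000 nM, between 4000 nM and 40000 nM.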

Compound 3, half-maximal inhibitory concentration: > 50000 nM
Compound 3 gave a limit, no number (the forecaster's own chance of this, stated with the estimate: 20%); middle value at least 4.1-fold (0.61 log units) away from the limit.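

In this assay the place on a nitrogen on an aromatic ring now shows a second change beyond the scatter (an at least 4.3-fold higher number from compound 2 to compound 3 (0.63 log units; beyond the scatter)), with 3,4,5-trimethoxyphenyl in place of 4-(trifluoromethyl)phenyl. The step between compound 1 and compound 3 cannot be read. Of the three groups shown at this place, only 4-(trifluoromethyl)phenyl gives a number, and the other two give limits: the limit of > 50000 nM in this assay, at which 2 of the 3 values shown sit. As far as these compounds go, whether a phenyl ring carrying a single methoxy or a chlorine gives a number in this assay stays open. So does whether any group at this place gives a lower number than compound 2.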